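This account rests on a few compounds, and the source may have more. Where it says the series, first, only, none or still open, it means among the compounds named here.

Working notes on the series.

For the measured compounds named here, compound 2 `N#Cc1cccc(Cc2cnc(CCc3ccc(-c4ccccc4C(=O)O)cc3)[nH]2)c1` gives the lowest number of the two measured so far in an in vitro functional assay on cells for agonist activity at Bombesin receptor subtype-3 (Homo sapiens), read by luminescence and calcium flux (a higher number here means that more compound is needed for the effect, a lower number that less compound is needed), at 812 nM. Going by the values given here, its only neighbour is compound 1 `CCCCc1cnc(CCc2ccc(-c3ccccc3C(=O)O)cc2)[nH]1`, which in this assay gives 2710 nM; the step of a 3.3-fold lower number from compound 1 to compound 2 (0.52 log units; beyond the scatter) is the single comparison available and it is beyond the scatter.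

Compound 3 `CCC(C)(CC)Cc1cnc(CCc2ccc(-c3ccccc3C(=O)O)cc2)[nH]1` has not been measured. Relative to compound 2 it carries 1-ethyl-1-methylpropyl in place of 3-cyanophenyl on a saturated chain carbon bound to an aromatic carbon. Among the compounds with values here, the only step that bears on this change is the one from compound 1 to compound 2, in which a 3-cyanophenyl arriving in place of propyl at the same saturated chain carbon lowered the number by a 3.3-fold lower number from compound 1 to compound 2 (0.52 log units; beyond the scatter). Compound 3 takes the 3-cyanophenyl away again and returns to a plain alkyl group, now 1-ethyl-1-methylpropyl rather than propyl, so the expectation is a step back upward, of roughly the same size as the earlier one, with wide uncertainty since no branched alkyl has been tested here. The expected step is a 2.7-fold higher number from compound 2 to compound 3 (0.43 log units; beyond the scatter). Compound 3 is accordingly estimated at 2200 nM, with a range from 600 nM to 7000 nM.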

Compound 3, half-maximal effective concentration: 76 nM
Compound 3: middle estimate off by 29-fold (1.46 log units), on the high side, outside the stated range (below it).
By their numbers in this assay, from the lowest: compound 3; then compound 2; then compound 1.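

At this saturated chain carbon bound to an aromatic carbon, the 3-cyanophenyl is not needed to reach a low number in this assay: replacing it with 1-ethyl-1-methylpropyl, which has no ring and no nitrile, gives an 11-fold lower number from compound 2 to compound 3 (1.03 log units; beyond the scatter). Alkyl groups at this place do not behave as one class either, since 1-ethyl-1-methylpropyl in place of propyl gives a 36-fold lower number from compound 1 to compound 3 (1.55 log units; beyond the scatter), and the aryl-bearing compound 2 falls between the two alkyl compounds, so the order does not divide alkyl from aryl. Nothing at hand accounts for either step.

The compounds shown do not separate the branching of 1-ethyl-1-methylpropyl from its size, as they include neither a straight hexyl chain nor a compact branched group such as tert-butyl or a cyclohexyl ring. Also open, on these data alone, is how the number responds when a hydroxyl or an amine is placed on the branched group, and whether a longer branched chain lowers it further or raises it again.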